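Replacing the amide aryl group on a shared sulfonamide core

A few compounds are considered here, and "the series" means these few. Any claim that something is new, unique, unknown or untested is made for them only; others in the source may bear on it.

Three measured compounds share one core and differ only at the amine nitrogen in a ring. Compound 1 `O=C(c1cccc(Cl)c1)N1CCC(NS(=O)(=O)c2cc(S(=O)(=O)c3ccccc3)ccc2C(F)(F)F)CC1` gives 300 nM in an assay on isolated protein for displacement of a labelled ligand from secreted frizzled-related protein 1 (Homo sapiens), read by fluorescence polarization, with a stated time of 30 min; a higher number here means a weaker inhibitor, a lower number a stronger inhibitor. Compound 2 `CN(C)c1ccc(C(=O)N2CCC(NS(=O)(=O)c3cc(S(=O)(=O)c4ccccc4)ccc3C(F)(F)F)CC2)cc1` gives 300 nM in this assay, and compound 3 `CC(C)(O)CCN1CCC(NS(=O)(=O)c2cc(S(=O)(=O)c3ccccc3)ccc2C(F)(F)F)CC1` gives 200 nM. Compound 2 stands level with compound 1 at the digits shown: the step of no change at the digits printed from compound 1 to compound 2 (within the scatter) lies within the scatter, and so do a 1.5-fold lower number from compound 2 to compound 3 (0.18 log units; within the scatter) and a 1.5-fold lower number from compound 1 to compound 3 (0.18 log units; within the scatter).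

Compound 4 `CC(C)(C)OC(=O)N1CC[C@H](C(=O)N2CCC(NS(=O)(=O)c3cc(S(=O)(=O)c4ccccc4)ccc3C(F)(F)F)CC2)C1` has not been measured. It differs from compound 2 by 1-(tert-butoxycarbonyl)pyrrolidin-3-yl in place of 4-(dimethylamino)phenyl on a carbonyl carbon. For the measured compounds named here, two measured steps bear on this place: the exchange of one aryl group for another in no change at the digits printed from compound 1 to compound 2 (within the scatter) and the removal of the whole acyl aryl group in a 1.5-fold lower number from compound 2 to compound 3 (0.18 log units; within the scatter) both stayed within the scatter. Going by the values given here, no measured step introduces a non-aromatic ring or a tert-butoxycarbonyl group here, so the expectation rests only on that indifference. Compound 4 is therefore expected to show a step of no change at the digits printed from compound 2 to compound 4 (within the scatter), nothing beyond the scatter. Compound 4 is estimated at 300 nM in this assay, with a range from 120 nM to 800 nM.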

Compound 4, half-maximal inhibitory concentration: 70 nM
For compound 4 the middle estimate is 4.3-fold (0.63 log units) above the measured one, outside the stated range (below it).
By their numbers in this assay, from the lowest: compound 4; then compounds 3, 1 and 2 (each within the scatter of the next).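

In this assay, for the compounds shown here, 1-(tert-butoxycarbonyl)pyrrolidin-3-yl on the carbonyl carbon produces the first steps at this position that lie beyond the scatter: a 4.3-fold lower number from compound 2 to compound 4 (0.63 log units; beyond the scatter) and a 4.3-fold lower number from compound 1 to compound 4 (0.63 log units; beyond the scatter). The position is therefore not indifferent to what the carbonyl carbon carries, as the two aryl amides alone suggested, and a group with a five-membered non-aromatic ring and a tert-butoxycarbonyl group can lower the number. Nothing measured here accounts for this step.

The compounds shown leave open whether the step belongs to the five-membered non-aromatic ring, to the tert-butoxycarbonyl group or to the two together. An acetyl group or a free ring amine in place of the tert-butoxycarbonyl group would separate these, and the opposite configuration at the defined stereocentre would show whether that centre matters.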